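A few compounds are considered here, and "the series" means these few. Any claim that something is new, unique, unknown or untested is made for them only; others in the source may bear on it.

- compound 1 `CN1CCN(C(=S)SCc2ccc3nc(N)nc(N)c3c2)CC1`: 9200 nM
- compound 2 `Nc1nc(N)c2cc(CSC(=S)N3CCN(c4ccc(O)cc4)CC3)ccc2n1`: 4210 nM

Within the data shown here, in a functional assay on A549 cells (Homo sapiens) for antiproliferative activity, read by MTT assay, with a stated time of 72 h (a lower number here means a stronger inhibitor, a higher number a weaker inhibitor), compound 2, at 4210 nM, has the lower of the two numbers so far. The next structure is compound 3 `Cc1ccccc1N1CCN(C(=S)SCc2ccc3nc(N)nc(N)c3c2)CC1`, with 2-methylphenyl in place of 4-hydroxyphenyl on an amine nitrogen in a ring. Among the measured compounds shown here, only one measured step bears on this, and only loosely. It is a 2.2-fold lower number from compound 1 to compound 2 (0.34 log units; beyond the scatter), a modest change made at the same place with 4-hydroxyphenyl in place of methyl. For the measured compounds named here, no measured step swaps one phenyl group for another, so no clear direction can be expected in this assay, and any change is expected to be small. The expected step is a 1.1-fold higher number from compound 2 to compound 3 (0.03 log units; within the scatter). For compound 3 the estimated value is 4500 nM, with an expected range of 1700 nM to 11000 nM.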

Compound 3, half-maximal inhibitory concentration: 3920 nM
Beside the measured number, compound 3's estimate is 1.1-fold (0.06 log units) above it; measured number inside the range.
By their numbers in this assay, from the lowest: compounds 3 and 2 (each within the scatter of the next); then compound 1.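

In this assay, a 1.1-fold lower number from compound 2 to compound 3 (0.03 log units; within the scatter) is a step within the scatter, so at this amine nitrogen 2-methylphenyl serves as well as 4-hydroxyphenyl, although it carries no hydrogen-bond donor or acceptor. The gain over methyl also holds for this second ring-bearing group, with a 2.3-fold lower number from compound 1 to compound 3 (0.37 log units; beyond the scatter) as a modest step beyond the scatter. Nothing measured here explains these numbers. Still open, as far as these compounds go, is how an unsubstituted phenyl, a cyclohexyl or a chain ending in a carboxylic acid would compare at this nitrogen.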